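Swapping an Ether for a Benzylthio Group on the Core

This account rests on a few compounds, and the source may have more. Where it says the series, first, only, none or still open, it means among the compounds named here.

Compound 2 `CC(C)Oc1nc(C(C)(C)C)ccc1CNC(=O)C(C)c1ccc(NS(C)(=O)=O)c(F)c1` stands second highest of three numbers in an assay on cells for antagonist activity at transient receptor potential cation channel subfamily V member 1 (Homo sapiens), read by FLIPR and calcium flux, with a stated time of 6 min (on this read-out lower numbers stand for stronger inhibition and higher numbers for weaker inhibition), where compound 2 gives 2.3 nM. Compound 1 `CCCOc1nc(C(C)(C)C)ccc1CNC(=O)C(C)c1ccc(NS(C)(=O)=O)c(F)c1` gives 1.7 nM, and compound 3 `CCOCCOc1nc(C(C)(C)C)ccc1CNC(=O)C(C)c1ccc(NS(C)(=O)=O)c(F)c1` gives 23.9 nM. The step of a 1.4-fold higher number from compound 1 to compound 2 (0.13 log units; within the scatter) is small, whereas a 10-fold higher number from compound 2 to compound 3 (1.02 log units; beyond the scatter) and a 14-fold higher number from compound 1 to compound 3 (1.15 log units; beyond the scatter) are both large. Compound 4 `CC(C(=O)NCc1ccc(C(C)(C)C)nc1SCc1ccccc1Cl)c1ccc(NS(C)(=O)=O)c(F)c1` differs from compound 2 in one place: (2-chlorobenzyl)sulfanyl in place of isopropoxy on an aromatic carbon. The measured steps show that a short branched chain at this place is tolerated while a longer chain is not, and the entering group is larger still. A weakening beyond the scatter is therefore expected, a 3.5-fold higher number from compound 2 to compound 4 (0.54 log units; beyond the scatter). Compound 4 is estimated at 8 nM, with a range from 2 nM to 40 nM.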

Compound 4, inhibition constant: 3.8 nM
The estimate for compound 4 lay 2.1-fold (0.32 log units) above the measured number, and the stated range covers the measured number.
By their numbers in this assay, from the lowest: compounds 1, 2 and 4 (each within the scatter of the next, the first and the last beyond it); then compound 3.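

In this assay, the larger (2-chlorobenzyl)sulfanyl group, which brings an aromatic ring, costs little against isopropoxy (a 1.7-fold higher number from compound 2 to compound 4 (0.22 log units; within the scatter)) and only modestly against propoxy (a 2.2-fold higher number from compound 1 to compound 4 (0.35 log units; beyond the scatter)). It also does much better than 2-ethoxyethoxy (a 6.3-fold lower number from compound 3 to compound 4 (0.80 log units; beyond the scatter)), so a bigger group at this place does not by itself give a much weaker number, and nothing measured here explains the difference. The compounds shown leave open whether the sulfur or the chlorine matters, which a benzyloxy or an unsubstituted benzylsulfanyl group at this place would help to separate.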